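This account rests on a few compounds, and the source may have more. Where it says the series, first, only, none or still open, it means among the compounds named here.

Compound 1 `COc1ccc(NC(=O)CN2CCN(c3nnc(Cc4ccncc4)c4ccccc34)CC2)cc1OC` gives 40100 nM
Compound 2 `COc1ccc(NC(=O)CN2CCN(c3nnc(Cc4ccccc4)c4ccccc34)CC2)cc1OC` gives 145000 nM

In a functional assay on HT-29 cells (Homo sapiens) for cytotoxicity, read by MTT assay, with a stated time of 72 h (a lower number here means a stronger inhibitor, a higher number a weaker inhibitor), compound 2 holds the higher of the two numbers, which makes it the weaker inhibitor of this pair. The next molecule, compound 3 `Cc1cccc(Cl)c1NC(=O)CN1CCN(c2nnc(Cc3ccccc3)c3ccccc23)CC1`, keeps the core of compound 2 and changes only the group on the amide-type nitrogen. The change is 2-chloro-6-methylphenyl in place of 3,4-dimethoxyphenyl on an amide-type nitrogen, with 2-chloro-6-methylphenyl in place of 3,4-dimethoxyphenyl.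

Within the data shown here, only one measured step is available as a guide, and it is a loose one: a 3.6-fold higher number from compound 1 to compound 2 (0.56 log units; beyond the scatter) is a modest move, made at a different place in the molecule. Among the measured compounds shown here, no measured step exists at the amide-type nitrogen, so the direction of this change is poorly founded. A step of similar size is expected, leaning towards a lower number because compound 2 at 145000 nM is the top of a very short range. The estimate for this change is a 2.4-fold lower number from compound 2 to compound 3 (0.38 log units; beyond the scatter). For compound 3 the expected value is 60000 nM, with an estimated range from 15000 nM to 200000 nM.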

Compound 3, half-maximal inhibitory concentration: 53600 nM
Estimate against measurement, compound 3: 1.1-fold (0.05 log units) above, within the range that was stated.
By their numbers in this assay, from the lowest: compounds 1 and 3 (each within the scatter of the next); then compound 2.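

In this assay, the amide-type nitrogen now has its first measured step: 2-chloro-6-methylphenyl in place of 3,4-dimethoxyphenyl gives a 2.7-fold lower number from compound 2 to compound 3 (0.43 log units; beyond the scatter). This shows that the group at this position affects the result, and that the shared core can take a different aromatic ring here without the number rising in this one case. The step is rated modest, as is a 3.6-fold higher number from compound 1 to compound 2 (0.56 log units; beyond the scatter) at the other place of change, so each of the two places has one modest step to its name, though no data here explain why the new group gives a lower number than the old one.

The swap removes both methoxy groups and brings in a chlorine and a methyl in one move, so the compounds shown cannot tell which of these parts accounts for the step; a plain phenyl, or a ring carrying only the chlorine or only the methyl, would separate them. Also open, on these data alone, is whether pyridin-4-yl in place of phenyl on the saturated chain carbon would shift the number in the same direction when 2-chloro-6-methylphenyl sits on the amide-type nitrogen.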